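Benzyloxy-imine series on bladder cells: methyl to chloro swap

A few compounds are considered here, and "the series" means these few. Any claim that something is new, unique, unknown or untested is made for them only; others in the source may bear on it.

Three compounds sharing a core of two fused aromatic bicycles joined through an oxime ether have been tested in a functional assay on T-24 cells (Homo sapiens) for cytotoxicity, read by MTT assay, with a stated time of 2 days; a lower number here means a stronger inhibitor, a higher number a weaker inhibitor. Compound 1 `O/N=C1/C(c2c[nH]c3ccc(OCc4ccccc4)cc23)=Nc2ccc(OCc3ccccc3)cc21` gives 11800 nM. Compound 2 `N#Cc1ccc2c(c1)/C(=N\OCc1ccccc1)C(c1c[nH]c3ccc(C#N)cc13)=N2` gives 18600 nM. Compound 3 `Cc1ccc(CO/N=C2/C(c3c[nH]c4ccc(Br)cc34)=Nc3ccc(Br)cc32)cc1` gives 21400 nM. The three numbers sit close together: the gap from compound 3 to compound 2 and the gap from compound 3 to compound 1 both fall inside the scatter of repeated measurements, so no ranking among them can be claimed.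

Compound 4 `Clc1cccc(CO/N=C2/C(c3c[nH]c4ccc(Br)cc34)=Nc3ccc(Br)cc32)c1` differs from compound 3 only at the benzyloxy end: 3-chlorophenyl in place of 4-methylphenyl on a saturated chain carbon bound to an oxygen on an unsaturated carbon. Among the measured compounds shown here, no measured pair here isolates such a change, so there is nothing in the data to suggest a departure from the narrow band occupied by compounds 1, 2 and 3. The expected step of a 1.1-fold lower number from compound 3 to compound 4 (0.03 log units; within the scatter) in this assay is therefore estimated to be none beyond the scatter. Compound 4 is expected to give 20000 nM, with a plausible range from 8000 nM to 50000 nM.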

Compound 4, half-maximal inhibitory concentration: 9340 nM
Compound 4: middle estimate off by 2.1-fold (0.33 log units), on the high side, within the range that was stated.
By their numbers in this assay, from the lowest: compounds 4, 1, 2 and 3 (each within the scatter of the next, the first and the last beyond it).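

In this assay, the benzyloxy end of the molecule is shown for the first time to affect the number: 3-chlorophenyl in place of 4-methylphenyl, on a saturated chain carbon bound to an oxygen on an unsaturated carbon, gives a 2.3-fold lower number from compound 3 to compound 4 (0.36 log units; beyond the scatter). Among the compounds shown here, the earlier compounds offered no pair differing in one place, so this modest step is the only reading of a single change. No measurement at hand accounts for the step.

The swap changes both the group and its place on the phenyl ring, and the two stay tangled unless 4-chlorophenyl or 3-methylphenyl is compared at this position. Also open, on these data alone, is how the number would respond to an amine or a carboxylic acid on that ring, or to a longer chain in place of the benzyl carbon.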